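The source may hold more compounds than are shown below. What is called first, only, known or untested is meant among the compounds shown, and "the series" means these compounds.

Compound 1 `Cc1cc(C)cc(S(=O)(=O)c2c(C(=O)NCN3CCCC3)[nH]c3ccc(Cl)c(F)c23)c1` and compound 2 `Cc1cc(C)cc(S(=O)(=O)c2c(C(=O)NCCOc3ccccc3)[nH]c3ccc(Cl)c(F)c23)c1` share one core and differ only in their amide side chain. In an ADME assay on CCRF-CEM cells (Homo sapiens) for cytotoxicity, read by cell counting (on this read-out higher numbers stand for lower toxicity in this test and lower numbers for higher toxicity in this test), compound 1 gives 9300 nM, and compound 2 gives 11000 nM. The change from compound 2 to compound 1 is pyrrolidin-1-yl in place of phenoxymethyl on a saturated chain carbon bound to an amide-type nitrogen, and it made a step of a 1.2-fold lower number from compound 2 to compound 1 (0.07 log units; within the scatter). Compound 3 `Cc1cc(C)cc(S(=O)(=O)c2c(C(=O)NCCOc3ccccc3)[nH]c3ccc([N+](=O)[O-])cc23)c1` carries the side chain of compound 2 on another core; how the two cores differ is not broken down here. In this assay compound 3 reached only the limit of the assay, > 500000 nM, and gave no number. Compound 4 `Cc1cc(C)cc(S(=O)(=O)c2c(C(=O)NCN3CCCC3)[nH]c3ccc([N+](=O)[O-])cc23)c1` is compound 3 with the same change as before, (pyrrolidin-1-yl in place of phenoxymethyl on a saturated chain carbon bound to an amide-type nitrogen). The step from compound 3 to compound 4 is expected to be a number no higher from compound 3 to compound 4 (the limit leaves the size open), resting on the earlier step of the same change, a 1.2-fold lower number from compound 2 to compound 1 (0.07 log units; within the scatter), which stayed within the scatter. Compound 3 stands at the limit of > 500000 nM in this assay, at which 1 of the 3 values shown sits. Compound 4 is therefore expected to reach that same limit, with an estimate of 500000 nM.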

Compound 4, half-maximal cytotoxic concentration: 12000 nM
The estimate for compound 4 lay 42-fold (1.62 log units) above the measured number, outside the stated range (below it).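

Putting pyrrolidin-1-yl in place of phenoxymethyl gave an at least 41-fold lower number from compound 3 to compound 4 (1.61 log units; beyond the scatter) in this assay, so the same change did not carry the same size from one core to the other: the same change on two cores in this assay, a 1.2-fold lower number (0.07 log units; within the scatter) from compound 2 to compound 1 and an at least 41-fold lower number (1.61 log units; beyond the scatter) from compound 3 to compound 4, at least 35-fold (1.54 log units) apart, beyond the scatter of two such steps. From the compounds shown here alone, compound 3 stands at a limit of the assay, > 500000 nM, which is not a number, so the full size of this step remains unknown. These two pairs show that the outcome of the change differs with the core, but they do not show which feature of the cores goes with that difference.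

The compounds shown leave open how piperidin-1-yl, or a longer chain carrying the pyrrolidin-1-yl, would behave on either core. They also leave open which single difference of the two cores goes with the larger step.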